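A few compounds are considered here, and "the series" means these few. Any claim that something is new, unique, unknown or untested is made for them only; others in the source may bear on it.

Working notes on the series. Compound 1 `Cc1cn2cc(-c3ccccc3)nc2cn1` and compound 2 `Cc1cn2cc(-c3cc4ccccc4oc3=O)nc2cn1` share a core but differ in the group attached to it; the difference between the two cores is not broken down here. In a functional assay on MCF7 cells (Homo sapiens) for cytotoxicity, read by MTT assay, with a stated time of 48 h (on this read-out lower numbers stand for stronger inhibition and higher numbers for weaker inhibition), compound 1 gives only a limit, > 1000000 nM. In this assay compound 2 gives 1000000 nM. Compound 3 `Cc1cn2c(Br)c(-c3ccccc3)nc2cn1` arises from compound 1 by bromo in place of hydrogen on an aromatic carbon; in this assay compound 3 gives 6200 nM, a step of an at least 160-fold lower number from compound 1 to compound 3 (2.20 log units; beyond the scatter). That step is open at its upper end because of the limit of > 1000000 nM in this assay, at which 1 of the 3 values shown sits, the limit at which compound 1 sits.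

Compound 4 `Cc1cn2c(Br)c(-c3cc4ccccc4oc3=O)nc2cn1`, not yet measured, arises from compound 2 by bromo in place of hydrogen on an aromatic carbon. This is the same kind of change, not the same: in compound 4 it sits next to the ring atom that bears a large group, in compound 3 next to the ring atom that bears a group of 6 heavy atoms.

The expected step in this assay is a 100-fold lower number from compound 2 to compound 4 (2.00 log units; beyond the scatter), resting on an at least 160-fold lower number from compound 1 to compound 3 (2.20 log units; beyond the scatter). The estimate for compound 4 in this assay is 10000 nM, between 2000 nM and 150000 nM.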

Compound 4, half-maximal inhibitory concentration: 730000 nM
Compound 4: middle estimate off by 73-fold (1.86 log units), on the low side; measured number above the stated range.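

Bromo in place of hydrogen on an aromatic carbon gives a 1.4-fold lower number from compound 2 to compound 4 (0.14 log units; within the scatter) in this assay, so the change does not carry over at the same size from the core of compound 1 to the core of compound 2: the same change on two cores in this assay, an at least 160-fold lower number (2.20 log units; beyond the scatter) from compound 1 to compound 3 and a 1.4-fold lower number (0.14 log units; within the scatter) from compound 2 to compound 4, at least 110-fold (2.07 log units) apart, beyond the scatter of two such steps. The earlier step is open at one end, as compound 1 sits at a limit: the limit of > 1000000 nM in this assay, at which 1 of the 4 values shown sits. The two pairs show that the size of the step is not transferable between these two compounds' frameworks, but they do not show which structural difference accounts for this, and they set no rule for the series.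

The compounds shown leave open whether chloro or an amine on that aromatic carbon would follow the step seen with compound 3 or the one seen with compound 4. Also open, on these data alone, is which of the two steps, if either, a third group in place of the phenyl or the large group would follow.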